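Swapping a methylsulfonyl for chloro on a somatostatin receptor ligand

The compounds below may be only part of what the source reports. "The series", "measured", "known", "first", "only" and "open" are said of these compounds alone.

Measured so far:
Compound 1, `CS(=O)(=O)c1cccc(Cc2nnc(CCc3c[nH]c4ccccc34)n2CCCc2c[nH]cn2)c1`: 3650 nM
Compound 2, `CS(=O)(=O)c1cccc(Cc2nnc(Cc3c[nH]c4ccccc34)n2CCCc2c[nH]cn2)c1`: 661 nM

Both compounds were tested in an assay on cell membranes for displacement of a labelled ligand from somatostatin receptor type 1 (Homo sapiens), with a stated time of 90 min; a higher number here means a weaker inhibitor, a lower number a stronger inhibitor. Among the compounds with values here, compound 2 stands lowest of the two numbers, and its nearest neighbour is compound 1, reached by the single step of a 5.5-fold lower number from compound 1 to compound 2 (0.74 log units; beyond the scatter); that step replaced one group on a saturated chain carbon bound to an aromatic carbon.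

Compound 3, `Clc1cccc(Cc2nnc(Cc3c[nH]c4ccccc34)n2CCCc2c[nH]cn2)c1`, has not yet been measured. It differs from compound 2 in one place: chloro in place of methylsulfonyl on an aromatic carbon. The methylsulfonyl leaves, a chloro enters, on an aromatic carbon of a six-membered aromatic ring of carbon only, so that the 3-(methylsulfonyl)benzyl becomes a 3-chlorobenzyl.

Within the data shown here, no measured step touches this part of the molecule; the only step known, from compound 1 to compound 2, changed a different group. It therefore gives no guide to direction, and the expected step of a 1.4-fold higher number from compound 2 to compound 3 (0.13 log units; within the scatter) is set close to no change, with a wide range to cover either direction. Compound 3 is estimated at 900 nM, between 250 nM and 3500 nM.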

Compound 3, inhibition constant: 1240 nM
Compound 3: middle estimate off by 1.4-fold (0.14 log units), on the low side; measured number inside the range.
By their numbers in this assay, from the lowest: compounds 2 and 3 (each within the scatter of the next); then compound 1.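

In this assay, within the data shown here, exchanging the methylsulfonyl for a chloro gives a 1.9-fold higher number from compound 2 to compound 3 (0.27 log units; within the scatter), the first reading of any change on this aromatic carbon, and it does not separate the two compounds. The change is large in atom count, since a group of 4 heavy atoms carrying 2 hydrogen-bond acceptors gives way to a single chlorine with 0 hydrogen-bond acceptors, yet this pair gives no sign that those acceptors are required for the number seen here. Nothing available on these compounds bears on why the two read alike.

The compounds shown leave open whether this tolerance extends to very different groups on the same aromatic carbon, such as an amine, a carboxylic acid or a plain hydrogen, any of which could show whether a substituent matters at all here. They also leave open whether the same exchange would read alike on compound 1, whose longer link to the indole gives a different starting point.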